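From compound 3 to compound 4: losing the phenoxy group

The compounds below may be only part of what the source reports. "The series", "measured", "known", "first", "only" and "open" are said of these compounds alone.

In an ADME assay on MT4 cells (Homo sapiens) for cytotoxicity, read by MTT assay, with a stated time of 96 h (a higher number here means that more compound is tolerated, a lower number that less compound is tolerated), compound 3 (`Cc1ccccc1C1CC(c2ccc(Oc3ccccc3)cc2)=NN1c1ccc(S(N)(=O)=O)cc1`) gives 36000 nM and compound 1 (`NS(=O)(=O)c1ccc(N2N=C(c3ccccc3)CC2c2ccccc2F)cc1`) gives 42000 nM while compound 2 (`Cc1ccc(C2CC(c3ccccc3)=NN2c2ccc(S(N)(=O)=O)cc2)cc1`) gives 40000 nM on the same measure. All three values lie within the scatter of one another, so compound 3 has no separate standing among them.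

Compound 4 (`Cc1ccccc1C1CC(c2ccccc2)=NN1c1ccc(S(N)(=O)=O)cc1`) differs from compound 3 by one change (hydrogen in place of phenoxy on an aromatic carbon): hydrogen in place of phenoxy on an aromatic carbon. Among the measured compounds shown here, no measured step covers this change directly. For the measured compounds named here, the only measured step is a 1.1-fold lower number from compound 1 to compound 2 (0.02 log units; within the scatter) and it lies within the scatter, but it concerns 4-methylphenyl in place of 2-fluorophenyl on a saturated ring carbon, so it bears on this change only indirectly. Compound 2 carries no phenoxy group and gives 40000 nM in this assay and this stays within the scatter of the value for compound 3.

No step beyond the scatter is therefore expected in this assay and no direction can be called. The expected change is a 1.1-fold higher number from compound 3 to compound 4 (0.05 log units; within the scatter) and it stays within the scatter. For compound 4 the estimated value is 40000 nM with an expected range from 24000 nM to 70000 nM in this series.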

Compound 4, half-maximal cytotoxic concentration: 43000 nM
The estimate for compound 4 lay 1.1-fold (0.03 log units) below the measured number; the range from low to high includes it.
By their numbers in this assay, from the lowest: compounds 3, 2, 1 and 4 (each within the scatter of the next).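

The exchange of phenoxy for hydrogen, on an aromatic carbon para to a large group, now has a direct reading: in this assay it gives a 1.2-fold higher number from compound 3 to compound 4 (0.08 log units; within the scatter), so in this pair the phenoxy group leaves the read-out unmoved beyond the scatter. The aryl group on the saturated ring carbon gives the same picture in two further pairs, with a 1.1-fold higher number from compound 2 to compound 4 (0.03 log units; within the scatter) for 2-methylphenyl in place of 4-methylphenyl, and a 1.0-fold higher number from compound 1 to compound 4 (0.01 log units; within the scatter) for methyl in place of fluoro on an aromatic carbon. No measurement at hand speaks to a cause for these flat steps.

Only phenoxy and hydrogen are shown at this position, so the outcome with an amine or a carboxylic acid there remains open. All four compounds also share the sulfonamide, and no step shown lies beyond the scatter, so it is open whether any change, such as a carboxylic acid in place of that group, would move the half-maximal cytotoxic concentration in this assay at all.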